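The source may report more compounds than this note shows. Statements on the series, on what has been measured and on what is new or still open speak of the compounds shown alone.

Measured so far:
Compound 1, `CC1CC/C(=N\Nc2cccc(Br)c2)c2ncc(C(=O)O)c(=O)n21`: 0.4 umol/kg
Compound 2, `CC1CC/C(=N\Nc2ccc(O)cc2)c2ncc(C(=O)O)c(=O)n21`: 1.7 umol/kg
Compound 3, `C[C@@H]1CC/C(=N\Nc2ccc(O)cc2)c2ncc(C(=O)O)c(=O)n21`: 0.14 umol/kg

All three compounds share one core and were tested in a functional assay on the whole organism for inhibition, with Rattus norvegicus as the target; on this read-out lower numbers stand for an effect already at smaller amounts and higher numbers for an effect only at larger amounts of compound. On these numbers compound 2 stands highest: the step of a 4.3-fold higher number from compound 1 to compound 2 (0.63 log units; beyond the scatter) is modest, and the step of a 12-fold lower number from compound 2 to compound 3 (1.08 log units; beyond the scatter) is large. The second step rests only on (the fact that one of compounds 2 and 3 is drawn with a defined configuration and the other without, at the place where they differ), so it says nothing about changes at the aromatic ring.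

Compound 4, `CC1CC/C(=N\Nc2ccc(C(=O)O)cc2)c2ncc(C(=O)O)c(=O)n21`, has not yet been measured. It differs from compound 2 by carboxy in place of hydroxy on an aromatic carbon, a carboxy in place of hydroxy on an aromatic carbon of a six-membered aromatic ring of carbon only. Among the compounds with values here, the only measured step that touches that ring is the one from compound 1 to compound 2, and it was modest. A change of comparable size, in either direction, is therefore the most that the data support; no step beyond the scatter can be firmly expected. Compound 4 is expected to give 2 umol/kg, with a range from 0.5 umol/kg to 8 umol/kg. The expected change is a 1.2-fold higher number from compound 2 to compound 4 (0.07 log units; within the scatter).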

Compound 4, dose for 50% inhibition: 7.6 umol/kg
Compound 4: the middle estimate sits 3.8-fold (0.58 log units) below what was measured; measured number inside the range.
By their numbers in this assay, from the lowest: compound 3; then compound 1; then compound 2; then compound 4.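

Within the data shown here, compound 2 and compound 4 differ only in the group on the aromatic ring, para to a large group, so this is the first step that changes the group while its place stays the same. In this assay, replacing hydroxy with carboxy gives a 4.5-fold higher number from compound 2 to compound 4 (0.65 log units; beyond the scatter), which shows that the group at this place matters: at this one place, the compound with carboxy needs a larger dose than the one with hydroxy.

The compounds shown leave open how an amine or a methoxy group would read at this same place, and whether the defined configuration of compound 3 would lower the number of the carboxy compound too. Nothing given here explains why carboxy raises the number.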